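A few compounds are considered here, and "the series" means these few. Any claim that something is new, unique, unknown or untested is made for them only; others in the source may bear on it.

Compounds measured so far:
- compound 1, `CCCC[C@H](NC(=O)[C@H](CCCCN)NC(=O)[C@H](CCCNC(=N)N)NC(=O)c1ccc(/C=C/C(N)=O)cc1)C(N)=O` — "impermeable" (no number reported), with no number given
- compound 2, `CCCC[C@H](NC(=O)[C@H](CCCCN)NC(=O)[C@H](CCCNC(=N)N)NC(=O)c1ccc(/C=C2\SC(=S)N(C3CCCCC3)C2=O)cc1)C(N)=O` — 1.82 10^-6 cm/s

In an ADME assay for permeability, using PAMPA (on this read-out higher numbers stand for higher permeability and lower numbers for lower permeability), compound 2 gives 1.82 10^-6 cm/s. For the measured compounds named here, this is the only numerical reading in the set; compound 1 was recorded only as "impermeable" (no number reported), without a number, so no sized step between the two can be drawn, and nothing can be said about how far apart they lie.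

Compound 3, `C=CCN1C(=O)/C(=C/c2ccc(C(=O)N[C@@H](CCCNC(=N)N)C(=O)N[C@@H](CCCCN)C(=O)N[C@@H](CCCC)C(N)=O)cc2)SC1=S`, has not been measured. It differs from compound 2 in one place: allyl in place of cyclohexyl on an amide-type nitrogen in a ring. The shared core and the three attached side chains are unchanged.

Going by the values given here, with only one number to lean on, the direction of the step is uncertain. A step down that stays close to the scatter seems the likelier outcome for compound 3, and the expected step is a 1.7-fold lower number from compound 2 to compound 3 (0.22 log units; within the scatter). For compound 3 in this assay the estimate is 1.1 10^-6 cm/s, with a range from 0.4 10^-6 cm/s to 2.6 10^-6 cm/s.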

Compound 3, apparent permeability: 0.42 10^-6 cm/s
Estimate against measurement, compound 3: 2.6-fold (0.42 log units) above; low and high end bracket the measured number.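

In this assay, for the compounds shown here, allyl in place of cyclohexyl on the amide-type nitrogen in the ring gives a 4.3-fold lower number from compound 2 to compound 3 (0.64 log units; beyond the scatter), which is the first sized step in this set. It shows that the read-out responds to the group at this position while the shared core and the three side chains stay the same, although the swap removes a six-membered ring of carbon, lowers the heavy-atom count and adds a double bond all at once, so this single step cannot separate those changes. Nothing available explains the step.

From the compounds shown here alone, it remains open whether a propyl chain, which has no double bond, would read closer to compound 2 or to compound 3. Going by these compounds, how a phenyl ring, a longer chain such as hexyl, or an amine at this position would read also remains open.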